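A few compounds are considered here, and "the series" means these few. Any claim that something is new, unique, unknown or untested is made for them only; others in the source may bear on it.

The measured compounds:

Compound 1 `NS(=O)(=O)c1ccc(-n2nc(-c3ccccc3)cc2-c2cc(O)ccc2O)cc1` — 88100 nM
Compound 2 `NS(=O)(=O)c1ccc(-n2nc(-c3ccc(Cl)cc3)cc2-c2cc(O)ccc2O)cc1` — 12000 nM
Compound 3 `CC(=O)NS(=O)(=O)c1ccc(-n2nc(-c3ccc(Cl)cc3)cc2-c2cc(O)ccc2O)cc1` — 23500 nM

In a functional assay on cells (Cancer cell lines, Homo sapiens) for cytotoxicity, read by sulforhodamine B assay, with a stated time of 48 h (a lower number here means a stronger inhibitor of growth, a higher number a weaker inhibitor of growth), compound 2 gives the lowest of the three numbers. Compound 3 sits closest to it, and a 2.0-fold higher number from compound 2 to compound 3 (0.29 log units; within the scatter) lies within the scatter, so the two cannot be ordered. Compound 1 sits furthest, and a 7.3-fold lower number from compound 1 to compound 2 (0.87 log units; beyond the scatter) is a modest step beyond the scatter.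

Compound 4 `NS(=O)(=O)c1ccc(-n2nc(-c3ccc(Cl)cc3)cc2C2=CC(=O)C=CC2=O)cc1` is reached from compound 2 by a group of 8 heavy atoms (6 carbon, 2 oxygen; one six-membered non-aromatic ring of carbon only) in place of a group of 8 heavy atoms (6 carbon, 2 oxygen; one six-membered aromatic ring of carbon only), on an aromatic carbon. Neither measured step speaks to this change: the step from compound 1 to compound 2 concerns the chloro on the aromatic carbon, and the step from compound 2 to compound 3 concerns the acetyl on the sulfonamide nitrogen; both leave the group on the five-membered ring untouched. With nothing comparable measured, the expectation for compound 4 in this assay is a step of a 1.2-fold lower number from compound 2 to compound 4 (0.08 log units; within the scatter) from compound 2, that is, none beyond the scatter, held with low confidence. Compound 4 is therefore expected to give about 10000 nM, in a range from 2500 nM to 40000 nM.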

Compound 4, concentration for 50% growth inhibition: 23100 nM
The estimate for compound 4 lay 2.3-fold (0.36 log units) below the measured number; measured number inside the range.
By their numbers in this assay, from the lowest: compounds 2, 4 and 3 (each within the scatter of the next); then compound 1.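

In this assay, putting the six-membered non-aromatic ring of carbon only in place of the 2,5-dihydroxyphenyl group, on the aromatic carbon of the five-membered ring, gives a 1.9-fold higher number from compound 2 to compound 4 (0.28 log units; within the scatter). At this position, then, the aromatic ring can give way to the non-aromatic one, and the hydrogen-bond donors can go from 2 to 0, without a difference that can be told from the scatter of this assay. Nothing at hand offers an explanation for this outcome.

Going by these compounds, whether a plain phenyl, a dimethoxyphenyl, an amine or a carboxylic acid on this same carbon would behave alike remains open. Also open, on these data alone, is whether the chloro would count alongside the non-aromatic ring as it does in a 7.3-fold lower number from compound 1 to compound 2 (0.87 log units; beyond the scatter).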